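Amino in place of fluoromethyl on the side chain

A few compounds are considered here, and "the series" means these few. Any claim that something is new, unique, unknown or untested is made for them only; others in the source may bear on it.

Going by the values given here, compound 2 `COc1ccc(F)cc1-c1cccc(-c2nn(CCCCF)c(=O)o2)c1` gives 51% in a functional assay on the whole organism (strain Wistar albino) for inhibition, with Rattus norvegicus as the target, read by paw edema, with stated times of 30 min and 1 h, at a dose of 10 mg/kg by the oral route (on this read-out higher numbers stand for more inhibition at the one dose given (going by the name of the read-out) and lower numbers for less inhibition), and compound 1 `COc1ccc(F)cc1-c1cccc(-c2nn(CCCC#N)c(=O)o2)c1` gives 44%; the single measured step, a number 7 percentage points higher from compound 1 to compound 2 (within the scatter), lies within the scatter, so the two compounds cannot be ranked. Compound 3 `COc1ccc(F)cc1-c1cccc(-c2nn(CCCN)c(=O)o2)c1` differs from compound 2 by amino in place of fluoromethyl on a saturated chain carbon, three bonds along the chain from an aromatic nitrogen. Among the compounds with values here, only that one step bears on the change, and it was small. Within the data shown here, neither measured compound carries an amino group, so no step of this kind is known. Compound 3 is therefore expected to stay near compound 2, with a number 3 percentage points lower from compound 2 to compound 3 (within the scatter) estimated as no change beyond the scatter. Compound 3 is estimated at 48%, within 33% to 63%.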

Compound 3, a percentage reported as inhibition, in the whole organism at one dose (the size of the read-out at that dose, not a potency): 43%
Beside the measured number, compound 3's estimate is 5 percentage points above it, and the stated range covers the measured number.
By their numbers in this assay, from the lowest: compounds 3, 1 and 2 (each within the scatter of the next).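

In this assay amino in place of fluoromethyl gives a number 8 percentage points lower from compound 2 to compound 3 (within the scatter) and amino in place of cyano gives a number 1 percentage points lower from compound 1 to compound 3 (within the scatter) so the three compounds cannot be ranked. On a saturated chain carbon, three bonds along the chain from an aromatic nitrogen, the entering amino group brings a hydrogen-bond donor that neither fluoromethyl nor cyano carries, and the read-out does not separate it from them. Nothing on hand explains these numbers.

From the compounds shown here alone, it stays open whether a carboxylic acid or a dimethylamino group at this place would part from these three compounds. Going by these compounds, a longer chain ending in amino is equally open.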